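Replacing 4-chloropyridin-3-yl with 5-bromothiophen-2-yl

A few compounds are considered here, and "the series" means these few. Any claim that something is new, unique, unknown or untested is made for them only; others in the source may bear on it.

- Compound 1 `CCCNc1ccc(NC(=O)c2cc(Cl)ccc2O)c(Cl)c1`: 22500 nM
- Compound 2 `O=C(Nc1ccc(NCc2cnccc2Cl)cc1Cl)c1cc(Cl)ccc1O`: 126000 nM

For the measured compounds named here, in an ADME assay on A549 cells (Homo sapiens) for cytotoxicity, read by resazurin assay, with a stated time of 48 h (on this read-out lower numbers stand for higher toxicity in this test and higher numbers for lower toxicity in this test), compound 2 gives 126000 nM, the higher of the two numbers so far, so it is the less toxic of the pair in this test. The next compound, compound 3 `O=C(Nc1ccc(NCc2ccc(Br)s2)cc1Cl)c1cc(Cl)ccc1O`, has not yet been measured. It carries 5-bromothiophen-2-yl in place of 4-chloropyridin-3-yl on a saturated chain carbon bound to a nitrogen on an aromatic ring.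

Going by the values given here, only one measured step bears on this change, and it lies at the same place: a 5.6-fold higher number from compound 1 to compound 2 (0.75 log units; beyond the scatter). Among the compounds with values here, this modest step shows that the number can move with the group at this place, but no measurement yet tests 5-bromothiophen-2-yl. The higher number arrived with 4-chloropyridin-3-yl, which now leaves, so a partial return toward compound 1 at 22500 nM is expected in this assay. The expected change is a 2.5-fold lower number from compound 2 to compound 3 (0.40 log units; beyond the scatter), smaller than the measured step and uncertain. For compound 3 the estimated value is 50000 nM, with an expected range from 15000 nM to 130000 nM.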

Compound 3, half-maximal cytotoxic concentration: 20700 nM
Compound 3: the middle estimate sits 2.4-fold (0.38 log units) above what was measured, and the stated range covers the measured number.
By their numbers in this assay, from the lowest: compounds 3 and 1 (each within the scatter of the next); then compound 2.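

In this assay, the place on a saturated chain carbon bound to a nitrogen on an aromatic ring now shows a second clear response to its group: 5-bromothiophen-2-yl in place of 4-chloropyridin-3-yl gives a 6.1-fold lower number from compound 2 to compound 3 (0.78 log units; beyond the scatter), which undoes the rise seen earlier as a 5.6-fold higher number from compound 1 to compound 2 (0.75 log units; beyond the scatter). The high number of compound 2 therefore does not come with just any aromatic ring at this place, since among the three groups shown it goes with 4-chloropyridin-3-yl alone, while 5-bromothiophen-2-yl and ethyl stand level, with a 1.1-fold lower number from compound 1 to compound 3 (0.04 log units; within the scatter). Nothing in the available data accounts for the gap between the two ring-bearing compounds.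

On these data alone, it remains open whether the number follows the ring or its halogen, a question that a plain pyridin-3-yl and a plain thiophen-2-yl, each without chlorine or bromine, would help to settle. As far as these compounds go, how an amine or a carboxylic acid on the ring, or a longer chain in place of ethyl, would read in this assay is also open.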